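A few compounds are considered here, and "the series" means these few. Any claim that something is new, unique, unknown or untested is made for them only; others in the source may bear on it.

In a functional assay on MGC-803 cells (Homo sapiens) for inhibition, read by sulforhodamine B assay (on this read-out lower numbers stand for stronger inhibition and higher numbers for weaker inhibition), compound 1 `COc1ccccc1NC1=CC(=O)c2c(nc3n2[C@H]2OC[C@@H](O)[C@H]2OC3)C1=O` gives 1670 nM, and compound 3 `CCOc1ccc(NC2=CC(=O)c3c(nc4n3[C@H]3OC[C@@H](O)[C@H]3OC4)C2=O)cc1` gives 2090 nM. Compound 3 therefore stands level with compound 1, with a 1.3-fold higher number from compound 1 to compound 3 (0.10 log units; within the scatter). Compound 2 `O=C1C(NC2CC2)=CC(=O)c2c1nc1n2[C@H]2OC[C@@H](O)[C@H]2OC1` is recorded only as a limit, > 4000 nM.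

The next change leads to compound 4 `O=C1C(Nc2cccc(Cl)c2)=CC(=O)c2c1nc1n2[C@H]2OC[C@@H](O)[C@H]2OC1`, with 3-chlorophenyl in place of 4-ethoxyphenyl on an amine nitrogen.

The closest measured precedent is the exchange of one substituted phenyl for another, a 1.3-fold higher number from compound 1 to compound 3 (0.10 log units; within the scatter). The steps involving cyclopropyl are less close, since compound 4 keeps a phenyl group: they are an at least 2.3-fold higher number from compound 1 to compound 2 (0.37 log units; beyond the scatter) and an at least 1.9-fold lower number from compound 2 to compound 3 (0.28 log units; that floor lies within the scatter). Among the measured compounds shown here, no measured compound carries a chlorine, so the range is kept wide.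

On this evidence, no change beyond the scatter is expected in this assay, and the expected step is a 1.2-fold lower number from compound 3 to compound 4 (0.09 log units; within the scatter). For compound 4 the estimated value is 1700 nM, with an expected range of 700 nM to 3900 nM.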

Compound 4, half-maximal inhibitory concentration: 1530 nM
Compound 4: middle estimate off by 1.1-fold (0.05 log units), on the high side; measured number inside the range.
By their numbers in this assay, from the lowest: compounds 4, 1 and 3 (each within the scatter of the next). At a limit, above all of these: compound 2.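

In this assay, 3-chlorophenyl on the amine nitrogen sits level with both alkoxy-bearing phenyl groups, so a chlorine-bearing phenyl group with no hydrogen-bond acceptor fits the same cluster: a 1.4-fold lower number from compound 3 to compound 4 (0.14 log units; within the scatter) and a 1.1-fold lower number from compound 1 to compound 4 (0.04 log units; within the scatter). Its separation from cyclopropyl is clear, with an at least 2.6-fold lower number from compound 2 to compound 4 (0.41 log units; beyond the scatter), as with 2-methoxyphenyl, whereas the floor for 4-ethoxyphenyl, an at least 1.9-fold lower number from compound 2 to compound 3 (0.28 log units; that floor lies within the scatter), does not clear the scatter. Compound 2 stands only as a limit: the limit of > 4000 nM in this assay, at which 1 of the 4 values shown sits.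

The three phenyl compounds differ in both substituent and its place on the ring, so neither factor can be read alone here. From the compounds shown here alone, it remains open whether a phenyl group bearing a nitrile, a carboxylic acid or an amine, or a longer alkyl chain in place of cyclopropyl, would leave this cluster.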